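Cyanophenyl position and tolerated concentration in the series

The compounds below may be only part of what the source reports. "The series", "measured", "known", "first", "only" and "open" are said of these compounds alone.

In an ADME assay on HeLa Rh cells (Homo sapiens) for cytotoxicity, read by microscopy (a lower number here means that less compound is tolerated, a higher number that more compound is tolerated), compound 1 `COc1cc(CC(O)c2ccc(-c3ccc(C#N)cc3)cc2)c([N+](=O)[O-])cc1OC` gives 4700 nM. Compound 2 `COc1cc(CC(O)c2ccc(-c3cccc(C#N)c3)cc2)c([N+](=O)[O-])cc1OC` carries a 3-cyanophenyl in place of the 4-cyanophenyl, and in this assay compound 2 gives 5200 nM. Within the data shown here, of the two numbers in hand compound 2 stands highest, with compound 1 nearest; the only measured step, a 1.1-fold higher number from compound 1 to compound 2 (0.04 log units; within the scatter), is within the scatter, so the two compounds are not separated by this read-out.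

Compound 3 `COc1cc(CC(O)c2ccc(-c3ccccc3C#N)cc2)c([N+](=O)[O-])cc1OC` is not yet measured. It differs from compound 2 by 2-cyanophenyl in place of 3-cyanophenyl on an aromatic carbon. Among the measured compounds shown here, the one measured step that bears on this move is the earlier shift of the nitrile around the same ring, a 1.1-fold higher number from compound 1 to compound 2 (0.04 log units; within the scatter), which was within the scatter. A further shift of the nitrile on that ring is therefore expected to leave the number in this assay unchanged beyond the scatter, though a single prior step is thin support. The expected step is a 1.0-fold lower number from compound 2 to compound 3 (0.02 log units; within the scatter). Compound 3 is accordingly estimated at 5000 nM, with a range from 2500 nM to 10000 nM.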

Compound 3, half-maximal cytotoxic concentration: 9300 nM
Beside the measured number, compound 3's estimate is 1.9-fold (0.27 log units) below it, and the stated range covers the measured number.
By their numbers in this assay, from the lowest: compounds 1, 2 and 3 (each within the scatter of the next).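

With 2-cyanophenyl in the series, all three placements of the nitrile on this ring now have a number in this assay, and two steps join the single one available earlier: a 1.8-fold higher number from compound 2 to compound 3 (0.25 log units; within the scatter) and, for the move from the 4-cyanophenyl, a 2.0-fold higher number from compound 1 to compound 3 (0.30 log units; within the scatter). Both steps lie within the scatter, so the 2-cyanophenyl, 3-cyanophenyl and 4-cyanophenyl forms are not separated by this read-out, and compound 1, compound 2 and compound 3 show no dependence on the place of the nitrile that can be told apart from repeat variation. No measurement shown here offers an explanation for these numbers.

All three compounds keep a nitrile on this ring and the same remaining core, so the series does not show whether the nitrile itself matters to the tolerated concentration in this assay. As far as these compounds go, whether a carboxylic acid, an amine or a longer chain in place of the nitrile would give a number beyond the scatter of these three remains open.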